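Amino group added to compound 2: expected cytotoxicity

The source may report more compounds than this note shows. Statements on the series, on what has been measured and on what is new or still open speak of the compounds shown alone.

Of the compounds shown here, three have numbers so far in a functional assay on MRC5 cells (Homo sapiens) for cytotoxicity; a lower number here means that less compound is tolerated, a higher number that more compound is tolerated. Compound 2 `O=C(NNC(=O)c1ccc([N+](=O)[O-])o1)c1ccc2ccccc2c1` gives 2000 nM, within the scatter of compound 1 `O=C(NNC(=O)c1ccc([N+](=O)[O-])o1)c1ccc([N+](=O)[O-])o1` at 4000 nM. Compound 3 `N[C@@H](C(=O)NNC(=O)c1ccc([N+](=O)[O-])o1)c1ccccc1` gives 14000 nM, a higher number, and that gap to compound 2 lies beyond the scatter. Compound 4 `Nc1ccc2cc(C(=O)NNC(=O)c3ccc([N+](=O)[O-])o3)ccc2c1` differs from compound 2 in one place: amino in place of hydrogen on an aromatic carbon. Going by the values given here, no measured pair isolates this change, so compound 2 at 2000 nM is the only anchor. The expected 1.3-fold higher number from compound 2 to compound 4 (0.10 log units; within the scatter) stays within the scatter. For compound 4 the estimated value in this assay is 2500 nM, with an expected range of 800 nM to 8000 nM.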

Compound 4, half-maximal cytotoxic concentration: 770 nM
Beside the measured number, compound 4's estimate is 3.2-fold (0.51 log units) above it; the measured number lies below the stated range.
By their numbers in this assay, from the lowest: compound 4; then compounds 2 and 1 (each within the scatter of the next); then compound 3.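

In this assay, going by these compounds alone, amino in place of hydrogen on this aromatic carbon gives a 2.6-fold lower number from compound 2 to compound 4 (0.41 log units; beyond the scatter) and provides the first single-place step. The position therefore responds to substitution: a single amino group leaves less compound tolerated, though the step is modest. No available data bear on the reason for this step.

A hydroxyl or dimethylamino group on the same aromatic carbon would test whether the step is specific to amino. Also open, as far as these compounds go, is whether amino on another carbon of that ring gives a step of similar size.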